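Phenyl for isopropyl on the sulfur: compound 3 to compound 4

The source may hold more compounds than are shown below. What is called first, only, known or untested is meant among the compounds shown, and "the series" means these compounds.

In an ADME assay on PBMC cells (Homo sapiens) for inhibition, read by MTT assay (on this read-out higher numbers stand for weaker inhibition and lower numbers for stronger inhibition), compound 1 `CC1=CCC[C@H]2[C@](C)(CC3=CC(=O)C(SC(C)(C)C)=CC3=O)[C@@H](C)CC[C@]12C` gives 20800 nM and compound 2 `CC1=CCC[C@H]2[C@](C)(CC3=CC(=O)C=CC3=O)[C@@H](C)CC[C@]12C` gives 4500 nM as its value. Among the compounds with values here, compound 3 `CC1=CCC[C@H]2[C@](C)(CC3=CC(=O)C(SC(C)C)=CC3=O)[C@@H](C)CC[C@]12C` has no number to place it, its entry being "not determined" (no result reported) with no measured step leading from it. Compound 4 `CC1=CCC[C@H]2[C@](C)(CC3=CC(=O)C(Sc4ccccc4)=CC3=O)[C@@H](C)CC[C@]12C` carries phenyl in place of isopropyl on a sulfur and is still to be measured. Within the data shown here, the one measured step touching this sulfur is a 4.6-fold lower number from compound 1 to compound 2 (0.66 log units; beyond the scatter) as hydrogen replaces (tert-butyl)sulfanyl on a double-bonded ring carbon. Among the measured compounds shown here, that step, modest and beyond the scatter, removes the whole sulfanyl group, and no measured pair swaps one group on the sulfur for another. With compound 3 lacking a number, no size or direction of step from it can be expected in this assay at this stage. For the measured compounds named here, the only measured compound with a group on this sulfur is compound 1 at 20800 nM and the expectation leans on it. Compound 4 is estimated at 14000 nM with an expected range from 4500 nM to 40000 nM as a working figure.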

Compound 4, half-maximal inhibitory concentration: 11200 nM
Compound 4: the middle estimate sits 1.3-fold (0.10 log units) above what was measured; the range from low to high includes it.
By their numbers in this assay, from the lowest: compound 2; then compounds 4 and 1 (each within the scatter of the next).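

In this assay, phenylsulfanyl in place of hydrogen on a double-bonded ring carbon gives a 2.5-fold higher number from compound 2 to compound 4 (0.40 log units; beyond the scatter) and this runs the same way as the step back from compound 2 to the tert-butylsulfanyl compound 1, so both sulfur-bearing compounds shown read above the compound with hydrogen there. Phenyl in place of tert-butyl on a sulfur gives a 1.9-fold lower number from compound 1 to compound 4 (0.27 log units; within the scatter) and, this being within the scatter, the two groups are not told apart on this read-out, the first measured swap of one group on the sulfur for another. No measurement bears on the reason for either step.

As far as these compounds go, the step from compound 3 to compound 4 cannot be read, so the place of isopropyl on the sulfur stays open. Also open, from the compounds shown here alone, is how a sulfur carrying an amine or a carboxylic acid would read against compound 2.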